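Extending the saturated chain of compound 2 by nonyl

The source may hold more compounds than are shown below. What is called first, only, known or untested is meant among the compounds shown, and "the series" means these compounds.

Among the measured compounds shown here, compound 2 `CCCCCCCCCCc1nc(N(C)C)c(C)c(C)c1O` gives 65% in a functional assay on cells (Lymphocyte, Homo sapiens) for inhibition, read by flow cytometry, using a membrane potential dye, with a stated time of 16 h, tested at 100 nM (a lower number here means a weaker effect, a higher number a stronger effect of the compound at the concentration tested), the highest of the two numbers measured so far; compound 1 `Cc1c(N(C)C)nc(CCCCCCCCCCO)c(O)c1C` gives 24%, and the step of a number 41 percentage points higher from compound 1 to compound 2 (beyond the scatter) was large. Compound 3 `CCCCCCCCCCCCCCCCCCCc1nc(N(C)C)c(C)c(C)c1O` differs from compound 2 by nonyl in place of hydrogen on a saturated chain carbon, ten or more bonds along the chain from an aromatic carbon. For the measured compounds named here, no measured step changes the length of the chain itself; the one step seen concerns hydroxy against hydrogen on the chain, so it bears on this change only loosely. The step of a number 5 percentage points lower from compound 2 to compound 3 (within the scatter) is expected to be small, in no clear direction and within the scatter. Compound 3 is therefore estimated at 60%, with a range from 35% to 85%.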

Compound 3, a percentage reported as activity, at one concentration (the size of the read-out at that concentration, not a potency): 24%
The estimate for compound 3 lay 36 percentage points above the measured number; the whole stated range lies above it.
By their numbers in this assay, from the lowest: compounds 1 and 3 (each within the scatter of the next); then compound 2.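

In this assay the chain does not tolerate unlimited growth: nonyl in place of hydrogen on a saturated chain carbon, ten or more bonds along the chain from an aromatic carbon, gives a number 41 percentage points lower from compound 2 to compound 3 (beyond the scatter) and so the higher number of compound 2 does not carry on with length. Nonyl in place of hydroxy at that place gives no change at the digits printed from compound 1 to compound 3 (within the scatter) and so two unlike changes to the chain of compound 2 end at the same level. No measurement at hand accounts for either step.

Where between these two chain lengths the read-out falls stays open. Going by these compounds, how an amine or a carboxylic acid at the chain end would compare with hydroxy also stays open.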